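Replacing Pyridin-2-yl in Compound 3 with 4-(Trifluoromethyl)phenyl

The source may report more compounds than this note shows. Statements on the series, on what has been measured and on what is new or still open speak of the compounds shown alone.

Of the compounds shown here, three on a shared core have been measured in an assay on HEK293 cells for activation of Kir3.1/Kir3.2 (Homo sapiens), read by thallium flux; on this read-out lower numbers stand for an effect already at smaller amounts and higher numbers for an effect only at larger amounts of compound. Compound 1 `Cc1cc(NC(=S)Cn2nnc(-c3ccccc3)n2)n(C2CCCCC2)n1` gives 623 nM in this assay, and compound 2 `CC1CC1c1cc(NC(=O)Cn2nnc(-c3ccccc3)n2)n(C2CCCCC2)n1` gives 843 nM. Compound 3 `Cc1cc(NC(=O)Cn2nnc(-c3ccccn3)n2)n(C2CCCCC2)n1` stands highest of the three with 14600 nM; its nearest neighbour is compound 2 and its furthest is compound 1, and both gaps lie beyond the scatter. Compound 4 `Cc1cc(NC(=O)Cn2nnc(-c3ccc(C(F)(F)F)cc3)n2)n(C2CCCCC2)n1` is not yet measured and differs from compound 3 in one place: 4-(trifluoromethyl)phenyl in place of pyridin-2-yl on an aromatic carbon. Compound 1, which carries a phenyl, gives 623 nM, and compound 2, also with a phenyl, gives 843 nM. On that basis a downward step of a 12-fold lower number from compound 3 to compound 4 (1.09 log units; beyond the scatter) is expected, beyond the scatter. Compound 4 is estimated at 1200 nM, within 400 nM to 4000 nM.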

Compound 4, half-maximal effective concentration: 241 nM
Compound 4: middle estimate off by 5.0-fold (0.70 log units), on the high side; the measured number lies below the stated range.
By their numbers in this assay, from the lowest: compound 4; then compounds 1 and 2 (each within the scatter of the next); then compound 3.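

In this assay the change of pyridin-2-yl to 4-(trifluoromethyl)phenyl on an aromatic carbon of the five-membered aromatic ring gives a 61-fold lower number from compound 3 to compound 4 (1.78 log units; beyond the scatter) and is a large step beyond the scatter. For the compounds shown here, this position therefore responds strongly to the group it carries, which the earlier compounds could not show. No available measurement accounts for the size of this step.

The step removes the ring nitrogen and adds the trifluoromethyl together, and the compounds shown do not separate these two changes. As far as these compounds go, how a chlorine or a methoxy group in place of the trifluoromethyl would read remains open.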